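Methyl on the benzyl ring of a triazole-linked flavanone

This account rests on a few compounds, and the source may have more. Where it says the series, first, only, none or still open, it means among the compounds named here.

The shared core of compound 1 `COc1ccc([C@@H]2CC(=O)c3c(O)cc(OCc4cn(Cc5ccccc5)nn4)cc3O2)cc1O` carries a benzyl group on a triazole ring. In a functional assay on RAW264.7 cells (Mus musculus) for inhibition, read by Griess assay, with stated times of 2 h and 24 h (a lower number here means a stronger inhibitor, a higher number a weaker inhibitor), compound 1 gives 11000 nM. Compound 2 `CCCCn1cc(COc2cc(O)c3c(c2)O[C@H](c2ccc(OC)c(O)c2)C/C3=N\O)nn1`, with a butyl chain on the triazole and an oxime in place of the ketone, gives 8900 nM in this assay, and the two numbers lie within the usual scatter of each other, so nothing separates them. Among the compounds with values here, no pair of measured compounds differs in one place, so no single step can be read from the data.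

Compound 3 `COc1ccc([C@@H]2CC(=O)c3c(O)cc(OCc4cn(Cc5ccc(C)cc5)nn4)cc3O2)cc1O` is the next point. Against compound 1 its change is methyl in place of hydrogen on an aromatic carbon on the benzyl ring. A single carbon added to the outer ring, with no change in donors, acceptors or charge, gives little reason for a large shift in either direction. The expected step of a 1.2-fold lower number from compound 1 to compound 3 (0.06 log units; within the scatter) is therefore none beyond the scatter. Compound 3 is expected to give about 9500 nM in this assay, with a range from 4000 nM to 25000 nM.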

Compound 3, half-maximal inhibitory concentration: 16800 nM
Compound 3: the middle estimate sits 1.8-fold (0.25 log units) below what was measured; the range from low to high includes it.
By their numbers in this assay, from the lowest: compounds 2, 1 and 3 (each within the scatter of the next).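

Within the data shown here, compound 3 gives the first step in this set that can be read in one place: in this assay, methyl in place of hydrogen on an aromatic carbon of the benzyl ring, para to a large group, gives a small difference (a 1.5-fold higher number from compound 1 to compound 3 (0.18 log units; within the scatter)). The step therefore does not separate 4-methylbenzyl from benzyl at this position, and in this assay the added carbon leaves no effect that can be told apart from repeat-measurement noise. No accompanying measurement bears on this result, so it can be reported only as a number.

The compounds shown leave open whether a group other than methyl at this position, such as an amine, a carboxylic acid or a longer chain, would move the number beyond the scatter, and whether methyl on another carbon of the benzyl ring would behave as it does here. Compound 2 differs from compound 1 and compound 3 in more than one place, so the separate contributions of its butyl chain and its oxime cannot be read.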